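This account rests on a few compounds, and the source may have more. Where it says the series, first, only, none or still open, it means among the compounds named here.

Compound 3 `Cc1cc(C2CS(=O)(=O)Oc3c2c(C2CC2)nn3-c2ccccc2Cl)ccc1Br` belongs to a set of three compounds built on one shared core and measured in a physicochemical assay for lipophilicity, using the shake flask method, in phosphate buffer, measured as octanol-water partition, with a stated time of 24 h, at pH 7.4; a lower number here means a more polar compound, a higher number a more lipophilic compound. Compound 1 `COc1ccc(-c2nn(-c3ccccc3F)c3c2C(c2ccc(Br)c(C)c2)CS(=O)(=O)O3)cc1` gives 2.91, compound 2 `Cc1cc(C2CS(=O)(=O)Oc3c2c(C)nn3-c2ccccc2F)ccc1Br` gives 2.26, and compound 3 gives 2.53. Compound 3 thus stands second highest of the three: its nearest neighbour is compound 2, whose number sits within the scatter of its own, and its furthest is compound 1, whose number lies beyond the scatter above it. Among the measured compounds shown here, the only single-site step measured so far, a number 0.65 log units lower from compound 1 to compound 2 (beyond the scatter), concerns the substituent on an aromatic carbon of the core and not the group on the saturated ring carbon.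

Compound 4 `O=S1(=O)CC(c2ccc(F)cc2)c2c(C3CC3)nn(-c3ccccc3Cl)c2O1` differs from compound 3 in that (4-fluorophenyl in place of 4-bromo-3-methylphenyl on a saturated ring carbon). For the measured compounds named here, no measured step touches this position, so the measured step serves only as a yardstick for how far numbers move within this set. Going by the values given here, with a bromine-bearing group leaving and a fluorine-bearing group entering, compound 4 is expected to give a lower number in this assay, by a step of a number 0.98 log units lower from compound 3 to compound 4 (beyond the scatter), larger than the one measured step. Compound 4 is therefore estimated at 1.55, with a range from 1.05 to 2.05.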

Compound 4, partition coefficient: 2.04
Compound 4: the middle estimate sits 0.49 log units below what was measured; the measured number falls inside the stated range.
By their numbers in this assay, from the lowest: compounds 4, 2 and 3 (each within the scatter of the next, the first and the last beyond it); then compound 1.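

At the saturated ring carbon, which the earlier step left untouched, the number in this assay proves responsive to the aryl group: a number 0.49 log units lower from compound 3 to compound 4 (beyond the scatter). This step comes from an exchange of one aryl group for another, with both groups counted as a six-membered aromatic ring of carbon only, with no hydrogen-bond donors or acceptors and no net charge, so a change in the aryl substituents alone is enough to carry the number beyond the scatter at this position. Nothing among the data shown accounts for why the number falls with this change.

Among the compounds shown here, the single step removes the bromine and the methyl and brings in the fluorine all at once, so how much of it belongs to each of these changes remains open, as does whether the same exchange would give a similar step with the other groups found on the aromatic carbon of the shared core. From the compounds shown here alone, how the number would respond to an amine or a carboxylic acid on the aryl group at the saturated ring carbon also remains unknown.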